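Trimming the side chain of a methyl propiolate ynone ester

The compounds below may be only part of what the source reports. "The series", "measured", "known", "first", "only" and "open" are said of these compounds alone.

This account follows a small series of methyl propiolate esters that carry an enol ether side chain, examined in a functional assay on HBL-100 cells (Homo sapiens) for antiproliferative activity, read by sulforhodamine B assay, with a stated time of 48 h; on this read-out higher numbers stand for weaker inhibition of growth and lower numbers for stronger inhibition of growth. Compound 1 `COC(=O)C#CC(O/C=C/C(=O)OC)C1CC1`, which bears a cyclopropyl group on the chain carbon, gives 250 nM in this assay. Compound 2 `COC(=O)C#CC(CCc1ccccc1)O/C=C/C(=O)OC`, in which a phenethyl chain replaces the cyclopropyl group, gives 2600 nM. Of the two numbers recorded, compound 2 stands highest, and its nearest neighbour, compound 1, lies well beyond the usual scatter below it.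

Compound 3 `COC(=O)C#CC(C)O/C=C/C(=O)OC` has not yet been measured. It differs from compound 2 in one place: hydrogen in place of benzyl on a saturated chain carbon, two bonds along the chain from an oxygen on an unsaturated carbon and a triple-bonded carbon. Among the compounds with values here, no measured pair reports this exact change, so the size of the step rests on expectation alone. Because compound 1 with its small group gives 250 nM while compound 2 with its larger chain gives 2600 nM, the author expects the number for compound 3 to fall below that of compound 2, a step of a 3.3-fold lower number from compound 2 to compound 3 (0.51 log units; beyond the scatter) being the estimate. Compound 3 is therefore expected to give about 800 nM in this assay, with a plausible range from 200 nM to 3000 nM.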

Compound 3, concentration for 50% growth inhibition: 300 nM
Compound 3: the middle estimate sits 2.7-fold (0.43 log units) above what was measured; measured number inside the range.
By their numbers in this assay, from the lowest: compounds 1 and 3 (each within the scatter of the next); then compound 2.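

In this assay, hydrogen in place of benzyl on a saturated chain carbon, two bonds along the chain from an oxygen on an unsaturated carbon and a triple-bonded carbon, gives an 8.7-fold lower number from compound 2 to compound 3 (0.94 log units; beyond the scatter), so this single change shifts growth inhibition by more than the usual scatter and shows that the chain end matters at this position. Methyl in place of cyclopropyl on a saturated chain carbon bound to an oxygen on an unsaturated carbon and a triple-bonded carbon gives a 1.2-fold higher number from compound 1 to compound 3 (0.08 log units; within the scatter), so this assay does not separate these two small groups. No measurement at hand explains either step.

The compounds shown cannot tell whether the larger step follows the six-membered aromatic ring or the length of the chain, a question that a plain butyl chain or a phenyl group set directly on the chain carbon would address. From the compounds shown here alone, how an amine or a carboxylic acid at the end of the chain would read in this assay also remains open.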